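This account rests on a few compounds, and the source may have more. Where it says the series, first, only, none or still open, it means among the compounds named here.

In a physicochemical assay for solubility, read by HPLC, in phosphate buffer, measured as thermodynamic solubility, with a stated time of 24 h, at pH 6.8 (a lower number here means a less soluble compound, a higher number a more soluble compound), the measured compounds read as follows:

compound 1 `C=CC(=O)N1CCC[C@@H](N2C(=O)N(Cc3ccccc3)Cc3cnc(Nc4ccc(N5CCN(C)CC5)cc4OC)nc32)C1` gives 142 ug/mL
compound 2 `C=CC(=O)N1CC[C@H](N2C(=O)N(Cc3ccccc3)Cc3cnc(Nc4ccc(N5CCN(C)CC5)cc4OC)nc32)C1` gives 107 ug/mL
compound 3 `C=CC(=O)N1CCC[C@H](N2C(=O)N(Cc3ccccc3)Cc3cnc(Nc4ccc(N5CCN(C)CC5)cc4OC)nc32)C1` gives 129 ug/mL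

Compound 2 stands within the scatter of both other compounds, so no order can be read among the three. Its two steps are a 1.3-fold lower number from compound 1 to compound 2 (0.12 log units; within the scatter) and a 1.2-fold higher number from compound 2 to compound 3 (0.08 log units; within the scatter) and the change of drawn configuration gives a 1.1-fold lower number from compound 1 to compound 3 (0.04 log units; within the scatter) as a third.

The next change lies elsewhere. Compound 4 `C=CC(=O)N1CC[C@H](N2C(=O)N(C)Cc3cnc(Nc4ccc(N5CCN(C)CC5)cc4OC)nc32)C1` differs from compound 2 by hydrogen in place of phenyl on a saturated chain carbon bound to an amide-type nitrogen in a ring in a change that reads as benzyl to methyl. The measured steps concern only the 1-(vinylcarbonyl)piperidin-3-yl and 1-(vinylcarbonyl)pyrrolidin-3-yl groups and their configuration, so none gives a size for this change. Among the compounds with values here, the sole anchor is compound 2 at 107 ug/mL and the range must stay wide. The estimated step is a 1.9-fold higher number from compound 2 to compound 4 (0.27 log units; within the scatter) as a modest expected rise. Compound 4 is expected at 200 ug/mL with an estimated range from 90 ug/mL to 450 ug/mL in this assay readings.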

Compound 4, solubility: 1250 ug/mL
Compound 4: the middle estimate sits 6.3-fold (0.80 log units) below what was measured, and the stated range ends below it.
By their numbers in this assay, from the lowest: compounds 2, 3 and 1 (each within the scatter of the next); then compound 4.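

In this assay, within the data shown here, the change of benzyl to methyl gives a 12-fold higher number from compound 2 to compound 4 (1.07 log units; beyond the scatter) and is the first step to lie beyond the scatter. The earlier steps touched only the 1-(vinylcarbonyl)piperidin-3-yl and 1-(vinylcarbonyl)pyrrolidin-3-yl groups and their configuration and all stayed within the scatter, so this position on the amide-type nitrogen in a ring is the first shown to carry a large step. The one available fact concerns a different pair of compounds and does not bear on this change.

With only benzyl and methyl shown here, it remains open how an ethyl group, a longer chain or a chain ending in an amine would read. Going by these compounds, it also remains open whether the same change gives a step of like size on the 1-(vinylcarbonyl)piperidin-3-yl compounds.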